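The source may report more compounds than this note shows. Statements on the series, on what has been measured and on what is new or still open speak of the compounds shown alone.

Among the measured compounds shown here, compound 3 `O=C(NO)c1ccc(NCc2nc(-c3ccccc3)nn2-c2ccc(C(F)(F)F)cc2)cc1` stands at the bottom of the three numbers measured so far: in an assay on Sf9 cells for inhibition of protein deacetylase HDAC6 (Homo sapiens), read by fluorescence, with a stated time of 40 min, tested at 100 nM (a lower number here means less inhibition, a higher number more inhibition at the concentration tested (going by the name of the read-out)), compound 3 gives 38.9%, whereas compound 2 `O=C(NO)c1ccc(NCc2nc(-c3ccccc3)nn2-c2ccc(Cl)cc2)cc1` gives 55.4% and compound 1 `O=C(NO)c1ccc(NCc2nc(-c3ccccc3)nn2-c2ccc(Br)cc2)cc1` gives 65.9%. Both steps that lead down to compound 3 are beyond the scatter, a number 27 percentage points lower from compound 1 to compound 3 (beyond the scatter) and a number 16.5 percentage points lower from compound 2 to compound 3 (beyond the scatter), and the step between the two halogen compounds, a number 10.5 percentage points lower from compound 1 to compound 2 (beyond the scatter), is also beyond it.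

Compound 4 `O=C(NO)c1ccc(NCc2nc(-c3ccccc3)nn2-c2ccccc2Cl)cc1` is reached from compound 3 by 2-chlorophenyl in place of 4-(trifluoromethyl)phenyl on an aromatic nitrogen. For the measured compounds named here, the steps that bear on this change are those in which trifluoromethyl was set against a halogen on the same ring, a number 27 percentage points lower from compound 1 to compound 3 (beyond the scatter) and a number 16.5 percentage points lower from compound 2 to compound 3 (beyond the scatter); both fell on arriving at trifluoromethyl, so giving it up in favour of chlorine points upward. Going by the values given here, the chlorine in compound 4, however, sits on a 2-chlorophenyl group rather than where compound 2 carries its chloro, and no measured pair shows what that rearrangement does, so the expectation is less firm than the two steps alone would suggest. Compound 4 is therefore expected to lie above compound 3 by a number 11.1 percentage points higher from compound 3 to compound 4 (beyond the scatter), a modest rise with wide uncertainty. The estimate for compound 4 is 50%, with a range from 30% to 70%.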

Compound 4, a percentage reported as inhibition, at one concentration (the size of the read-out at that concentration, not a potency): 64.6%
Compound 4: the middle estimate sits 14.6 percentage points below what was measured, within the range that was stated.
By their numbers in this assay, from the lowest: compound 3; then compounds 2, 4 and 1 (each within the scatter of the next, the first and the last beyond it).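

Among the compounds shown here, the swap of 2-chlorophenyl for 4-chlorophenyl on the aromatic nitrogen is the first pair that moves a halogen around this ring while keeping the halogen itself, and in this assay it gives a number 9.2 percentage points higher from compound 2 to compound 4 (within the scatter), so moving the chlorine makes no difference that can be told apart in this read-out. The 2-chlorophenyl group also cannot be told apart from 4-bromophenyl, with a number 1.3 percentage points lower from compound 1 to compound 4 (within the scatter), but it does stand clear of 4-(trifluoromethyl)phenyl, with a number 25.7 percentage points higher from compound 3 to compound 4 (beyond the scatter), which leaves compound 3 as the only one of the three earlier compounds separated from compound 4, even though compound 1 and compound 2 are separated from each other. Nothing at hand explains these differences.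

The compounds shown leave open whether bromo or trifluoromethyl, placed where 2-chlorophenyl carries its chlorine, would track the chloro result or keep the gaps seen among the earlier compounds. They also leave open how an amine, a methoxy group or a carboxylic acid on this ring would read out, and how any of these compounds would compare at other concentrations.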